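From a methyl to a propyl on the aromatic nitrogen

The source may hold more compounds than are shown below. What is called first, only, known or untested is meant among the compounds shown, and "the series" means these compounds.

Of the compounds shown here, two built on a shared core have been measured so far. Compound 1 `CN1CCN(CNC(=O)n2c(=O)n(C3CC3)c3ccccc32)CC1` gives 49.4 nM in an assay on isolated protein (striatum) for binding affinity to 5-hydroxytryptamine receptor 4 (Cavia porcellus), read by radioligand binding; on this read-out lower numbers stand for stronger inhibition and higher numbers for weaker inhibition. Among the measured compounds shown here, compound 2 `CN1CCN(CCNC(=O)n2c(=O)n(C)c3ccccc32)CC1` gives 306 nM in this assay, and so compound 2 stands with the higher of the two numbers; the two values lie apart by more than the usual scatter, but the two structures differ in more than one place, so no single step joins them. Compound 3 `CCCn1c(=O)n(C(=O)NCCN2CCN(C)CC2)c2ccccc21` has not yet been measured. It differs from compound 2 in one place only: ethyl in place of hydrogen on a saturated chain carbon bound to an aromatic nitrogen. For the measured compounds named here, no measured pair shows this change by itself, so its size is uncertain. The account expects the step from compound 2 to compound 3 to be of modest size toward a lower number, a 2.4-fold lower number from compound 2 to compound 3 (0.37 log units; beyond the scatter), because compound 1 with its own variations of the same core reaches 49.4 nM and shows that the core tolerates change there. Compound 3 is therefore estimated at 130 nM, with a range from 40 nM to 400 nM.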

Compound 3, inhibition constant: 253 nM
For compound 3 the middle estimate is 1.9-fold (0.29 log units) below the measured one, and the stated range covers the measured number.
By their numbers in this assay, from the lowest: compound 1; then compounds 3 and 2 (each within the scatter of the next).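

In this assay, among the compounds shown here, the change of ethyl in place of hydrogen on a saturated chain carbon bound to an aromatic nitrogen now has a measured size of its own, a 1.2-fold lower number from compound 2 to compound 3 (0.08 log units; within the scatter), where no single step had been available before. Going from the methyl of compound 2 to the propyl of compound 3 thus adds 2 carbon atoms at this position without moving the number outside the usual scatter, so on this read-out the two compounds cannot be told apart. No measurement shown offers any explanation for this flat step, and nothing available bears on why the result came out this way.

Compound 1 carries a different group at this position but also differs from compound 2 and compound 3 elsewhere, so its lower number cannot be credited to that group alone. As far as these compounds go, whether the flat response extends to a longer chain such as butyl, or to a chain ending in a hydroxyl group or an amine, remains open.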